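A few compounds are considered here, and "the series" means these few. Any claim that something is new, unique, unknown or untested is made for them only; others in the source may bear on it.

For the measured compounds named here, in a functional assay on CCRF-CEM cells (Homo sapiens) for antiproliferative activity (on this read-out higher numbers stand for weaker inhibition and lower numbers for stronger inhibition), compound 2 (`COc1cc(C(=O)c2sc(-c3ccc(F)cc3)cc2N)cc(OC)c1OC`) gives 15 nM, the lower of the two numbers so far, while compound 1 (`COc1cc(C(=O)c2sc(-c3ccc(I)cc3)cc2N)cc(OC)c1OC`) gives 150 nM. Compound 3 (`COc1cc(C(=O)c2sc(-c3ccc(C(F)(F)F)cc3)cc2N)cc(OC)c1OC`) differs from compound 2 at that same aromatic carbon: trifluoromethyl in place of fluoro on an aromatic carbon. The group enters para to a large group. Going by the values given here, only one measured step bears on this change, a 10-fold lower number from compound 1 to compound 2 (1.00 log units; beyond the scatter), with fluoro in place of iodo. That single pair suggests a move away from fluoro toward a higher number in this assay, though probably a somewhat smaller one. The estimated step is a 4.7-fold higher number from compound 2 to compound 3 (0.67 log units; beyond the scatter). Compound 3 is expected at 70 nM, with an estimated range of 20 nM to 250 nM.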

Compound 3, half-maximal inhibitory concentration: 270 nM
Compound 3: middle estimate off by 3.9-fold (0.59 log units), on the low side; the whole stated range lies below it.
By their numbers in this assay, from the lowest: compound 2; then compounds 1 and 3 (each within the scatter of the next).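

In this assay, trifluoromethyl in place of fluoro on this aromatic carbon gives an 18-fold higher number from compound 2 to compound 3 (1.26 log units; beyond the scatter), so fluoro now stands apart from two different replacements rather than one. Trifluoromethyl and iodo cannot be told apart here, with a 1.8-fold higher number from compound 1 to compound 3 (0.26 log units; within the scatter) lying within the scatter. No available evidence accounts for the gap between fluoro and these two groups.

From the compounds shown here alone, whether chloro, methoxy or an amine at this carbon would fall near compound 2 or near compounds 1 and 3 remains open. The compounds shown also do not say how the unsubstituted phenyl compares.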